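This account rests on a few compounds, and the source may have more. Where it says the series, first, only, none or still open, it means among the compounds named here.

In an ADME assay on a cell-free system (plasma, Homo sapiens) for metabolic stability, read by LC-MS (a higher number here means that the compound lasts longer, a lower number that the compound disappears faster), the compounds stand as follows:
- Compound 1 `NCc1ccc(C(=O)Nc2ccncc2F)cc1-c1cccc(C(=O)OCC2CC2)c1` gives 0.3 h
- Compound 2 `CC(C)OCCOC(=O)c1cccc(-c2cc(C(=O)Nc3ccncc3F)ccc2CN)c1` gives 0.1 h
- Compound 3 `NCc1ccc(C(=O)Nc2ccncc2F)cc1-c1cccc(C(=O)OCC2CCCCO2)c1` gives 0.117 h
- Compound 4 `NCc1ccc(C(=O)Nc2ccncc2F)cc1-c1cccc(C(=O)OC2CCCOC2)c1` has no measurement yet

Compound 3 is not separated from its closest neighbour: the data show a 1.2-fold higher number from compound 2 to compound 3 (0.07 log units; within the scatter). Against the top of the set they show a 2.6-fold lower number from compound 1 to compound 3 (0.41 log units; beyond the scatter).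

The change now in view is oxan-3-yl in place of (oxan-2-yl)methyl on an oxygen next to a carbonyl group, in words oxan-3-yl in place of (oxan-2-yl)methyl on an oxygen next to a carbonyl group. Every measured step swaps only the group on the saturated chain carbon bound to that oxygen, while the carbon itself stays. These steps therefore bear on the new change only indirectly. The largest of them is modest: a 3.0-fold lower number from compound 1 to compound 2 (0.48 log units; beyond the scatter). Within the data shown here, a step no larger than that is expected, with a slight lean upward that is weakly held, as the data contain no direct precedent. The estimated step is a 1.7-fold higher number from compound 3 to compound 4 (0.23 log units; within the scatter). Compound 4 is expected at 0.2 h, with an estimated range of 0.07 h to 0.6 h.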

Compound 4, half-life: 0.3 h
Beside the measured number, compound 4's estimate is 1.5-fold (0.18 log units) below it; measured number inside the range.
By their numbers in this assay, from the lowest: compounds 2 and 3 (each within the scatter of the next); then compounds 1 and 4 (each within the scatter of the next).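

In this assay, among these compounds, there is a 2.6-fold higher number from compound 3 to compound 4 (0.41 log units; beyond the scatter) when oxan-3-yl takes the place of (oxan-2-yl)methyl on the oxygen next to a carbonyl group, the first measured step in which the chain carbon bound to that oxygen does not stay. The same group gives a 3.0-fold higher number from compound 2 to compound 4 (0.48 log units; beyond the scatter) against 2-isopropoxyethyl, while against cyclopropylmethyl there is no change at the digits printed from compound 1 to compound 4 (within the scatter) in the record, so compound 3 and compound 4 do not stand together although each carries a six-membered non-aromatic ring with 1 hetero atom. Nothing measured here explains these steps.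

The compounds shown cannot separate the effect of the ring's attachment point from that of the lost chain carbon, since they hold neither oxan-4-yl nor (oxan-3-yl)methyl. Nor do they show where this assay would place an amine or a longer chain on that oxygen.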